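A 4-methylpiperazin-1-yl swap on the shared core

The source may hold more compounds than are shown below. What is called first, only, known or untested is meant among the compounds shown, and "the series" means these compounds.

Measured so far in a functional assay on A549 cells (Homo sapiens) for inhibition, read by colorimetric assay and MTT assay, with a stated time of 72 h; a higher number here means a weaker inhibitor, a lower number a stronger inhibitor
compound 1 `C/C1=C\CC[C@@]2(C)O[C@@H]2[C@H]2OC(=O)[C@@H](CN3CCCC3)[C@@H]2C[C@@H]1O` gives 9000 nM
compound 2 `C/C1=C\CC[C@@]2(C)O[C@@H]2[C@H]2OC(=O)[C@@H](CN3CCCCC3)[C@@H]2C[C@@H]1O` gives 6000 nM

Only these two numbers are available, and compound 2 at 6000 nM stands within the scatter of compound 1. Compound 3 `C/C1=C\CC[C@@]2(C)O[C@@H]2[C@H]2OC(=O)[C@@H](CN3CCN(C)CC3)[C@@H]2C[C@@H]1O` has not yet been measured. It carries 4-methylpiperazin-1-yl in place of piperidin-1-yl on a saturated chain carbon bound to a saturated ring carbon, and the change reads 4-methylpiperazin-1-yl in place of piperidin-1-yl on a saturated chain carbon bound to a saturated ring carbon in full. Among the compounds with values here, one measured step bears on it, at the same place, namely a 1.5-fold lower number from compound 1 to compound 2 (0.18 log units; within the scatter) for a different ring exchange. With that single step as a guide, no step beyond the scatter is expected in this assay in either direction. The expected change is a 1.2-fold higher number from compound 2 to compound 3 (0.07 log units; within the scatter) at most a small one. For compound 3 the estimated value is 7000 nM with an expected range from 3000 nM to 16000 nM in this measurement.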

Compound 3, half-maximal inhibitory concentration: 25000 nM
Compound 3: the middle estimate sits 3.6-fold (0.55 log units) below what was measured; measured number outside the range, above it.
By their numbers in this assay, from the lowest: compounds 2 and 1 (each within the scatter of the next); then compound 3.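

In this assay the amine ring on a saturated chain carbon bound to a saturated ring carbon proves not to be freely exchangeable: 4-methylpiperazin-1-yl in place of piperidin-1-yl gives a 4.2-fold higher number from compound 2 to compound 3 (0.62 log units; beyond the scatter) and in place of pyrrolidin-1-yl gives a 2.8-fold higher number from compound 1 to compound 3 (0.44 log units; beyond the scatter) at the same place. Compound 1 and compound 2 lie within the scatter of each other, so the two rings with one nitrogen showed no sensitivity here, whereas compound 3, with two ring nitrogens, is the weakest inhibitor of the three. Nothing given here accounts for this step.

The compounds shown do not separate the effect of the second ring nitrogen from that of its methyl. As far as these compounds go, how a piperazin-1-yl group without the methyl, a morpholin-4-yl group or an open-chain dimethylamino group would read at this place remains open.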